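Shrinking the Ring and Adding Fluorine on the Amide

The source may report more compounds than this note shows. Statements on the series, on what has been measured and on what is new or still open speak of the compounds shown alone.

Compound 2 `O=C(C1CCC1)N1CC2CC(C1)N2` is the weaker of the two measured compounds: in an assay on CHO cells for agonist activity at Neuronal acetylcholine receptor; alpha3/alpha6/beta2/beta3 (Homo sapiens), read by FLIPR and calcium flux (a lower number here means a smaller maximal response, a higher number a larger maximal response), compound 2 gives 80%, while compound 1 `CCC(=O)N1CC2CC(C1)N2` gives 120%. Within the data shown here, the one measured step, a number 40 percentage points lower from compound 1 to compound 2 (beyond the scatter), is the only change of the group on the carbonyl carbon known so far, and it runs opposite to growth of that group. Compound 3 `O=C([C@@H]1C[C@H]1F)N1CC2CC(C1)N2` carries a further change at the same place: 2-fluorocyclopropyl in place of cyclobutyl on a carbonyl carbon. Among the measured compounds shown here, no measured step tells how a three-membered ring or a fluorine at this position behaves, so the expectation leans on compound 1 and compound 2 alone. Since the entering group is a ring, as in compound 2, yet smaller, a modest rise back toward compound 1 is expected, a number 15 percentage points higher from compound 2 to compound 3 (beyond the scatter), and compound 3 is estimated at 95%, between 65% and 125%.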

Compound 3, largest response reached (Emax), in percent of the reference or control that the assay uses: 130%
Estimate against measurement, compound 3: 35 percentage points below, outside the stated range (above it).
By their numbers in this assay, from the lowest: compound 2; then compounds 1 and 3 (each within the scatter of the next).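

In this assay the exchange of cyclobutyl for 2-fluorocyclopropyl on a carbonyl carbon gives a number 50 percentage points higher from compound 2 to compound 3 (beyond the scatter) even though both groups hold 4 heavy atoms, so at this position the response is not set by that count alone. The exchange of ethyl for 2-fluorocyclopropyl gives a number 10 percentage points higher from compound 1 to compound 3 (within the scatter) and leaves compound 1 and compound 3 indistinguishable here, which shows that a ring on this carbonyl carbon does not by itself bring the lower number seen with compound 2. Nothing measured here accounts for this difference between the two rings.

Whether the fluorine or the three-membered ring carries the step remains open; plain cyclopropyl and the mirror-image 2-fluorocyclopropyl stand outside the compounds shown. Also open, from the compounds shown here alone, is how an amine, a methoxy group or a longer chain would behave on the same carbonyl carbon.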